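Swapping 3,4,5-trimethoxyphenyl for 3-methoxyphenyl

A few compounds are considered here, and "the series" means these few. Any claim that something is new, unique, unknown or untested is made for them only; others in the source may bear on it.

Compound 1 `COc1cc([C@@H]2[C@H](Oc3ccccc3)C(=O)N2c2cc(OC)c(OC)c(OC)c2)cc(OC)c1OC`: 29000 nM
Compound 2 `COc1ccc([C@@H]2[C@@H](Oc3ccccc3)C(=O)N2c2cc(OC)c(OC)c(OC)c2)cc1`: 6900 nM

Both values come from a functional assay on MCF7 cells (Homo sapiens) for antiproliferative activity, read by MTT assay, with stated times of 24 h and 72 h (on this read-out higher numbers stand for weaker inhibition and lower numbers for stronger inhibition), and compound 1 holds the higher of the two, so it is the weaker inhibitor here, with compound 2 lower by more than the usual scatter. Compound 3 `COc1cccc([C@@H]2[C@H](Oc3ccccc3)C(=O)N2c2cc(OC)c(OC)c(OC)c2)c1` has not been measured yet. It keeps the core of compound 1 but carries 3-methoxyphenyl in place of 3,4,5-trimethoxyphenyl on a saturated ring carbon. For the measured compounds named here, no measured pair shows this exact change. Compound 2 also lacks the 3,4,5-trimethoxyphenyl in that place, and compound 2 gives 6900 nM in this assay, which is the only hint available. The expected step is a 3.2-fold lower number from compound 1 to compound 3 (0.51 log units; beyond the scatter) toward stronger inhibition, a loose expectation resting on that one comparison. Compound 3 is estimated at 9000 nM (range 2500 nM to 30000 nM).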

Compound 3, half-maximal inhibitory concentration: 171000 nM
Compound 3: middle estimate off by 19-fold (1.28 log units), on the low side; the measured number lies above the stated range.
By their numbers in this assay, from the lowest: compound 2; then compound 1; then compound 3.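

In this assay, trimming 3,4,5-trimethoxyphenyl down to 3-methoxyphenyl on this saturated ring carbon gives a 5.9-fold higher number from compound 1 to compound 3 (0.77 log units; beyond the scatter), so inhibition weakens by more than the usual scatter. This position is therefore not indifferent to the group it carries, and removing methoxy groups here does not in itself bring stronger inhibition, even though compound 1 was the weaker of the first two compounds. Nothing available explains why the number rises with this change.

This single step cannot show which of the lost methoxy groups matters, or whether the loss of size or of the oxygen atoms counts more. It also leaves open how a 3-hydroxyphenyl or a 3-aminophenyl group would behave on the same ring carbon of the core of compound 1.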